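Replacing naphthalen-1-yl with 4-fluorophenyl in compound 2

A few compounds are considered here, and "the series" means these few. Any claim that something is new, unique, unknown or untested is made for them only; others in the source may bear on it.

Measured in a functional assay on HL-60 cells (Homo sapiens) for inhibition, read by CCK-8 assay, with a stated time of 48 h, tested at 20 uM; a lower number here means less inhibition of growth, a higher number more inhibition of growth at the concentration tested
Compound 1 `Cc1ccc(S(=O)(=O)Oc2ccccc2/C=C(\C#N)C(=O)Nc2nnc(C)s2)cc1` gives 78%
Compound 2 `Cc1ccc(S(=O)(=O)Oc2ccccc2/C=C(\C#N)C(=O)Nc2nnc(Cc3cccc4ccccc34)s2)cc1` gives 19%
Compound 3 `N#C/C(=C\c1ccccc1OS(=O)(=O)c1ccc(F)cc1)C(=O)Nc1nnc(Cc2cccc3ccccc23)s1` gives 12%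

Compound 2 stands within the scatter of compound 3 and far lower than compound 1. Compound 4 `Cc1ccc(S(=O)(=O)Oc2ccccc2/C=C(\C#N)C(=O)Nc2nnc(Cc3ccc(F)cc3)s2)cc1` differs from compound 2 in one place (4-fluorophenyl in place of naphthalen-1-yl on a saturated chain carbon bound to an aromatic carbon): 4-fluorophenyl in place of naphthalen-1-yl on a saturated chain carbon bound to an aromatic carbon. The step at this same place is large (a number 59 percentage points lower from compound 1 to compound 2 (beyond the scatter)). The step of fluoro in place of methyl on an aromatic carbon gives little guidance (a number 7 percentage points lower from compound 2 to compound 3 (within the scatter)). Since an aromatic group remains, only a moderate rise is expected (a number 13 percentage points higher from compound 2 to compound 4 (beyond the scatter)). For compound 4 the estimated value is 32% (range 12% to 60%).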

Compound 4, percent growth inhibition at one concentration: "not active" (no number reported)
For compound 4 the study gives words and no number, and the estimate cannot be compared.
By their numbers in this assay, from the lowest: compounds 3 and 2 (each within the scatter of the next); then compound 1.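

Within the data shown here, compound 4 is reported in this assay only as "not active", without a number, so no step from compound 2 to compound 4 can be read. No measured evidence bears on this result. The compounds shown leave open how far growth inhibition by compound 4 lies from that of compound 2.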